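Notes on the group at the sulfonyl sulfur

The source may report more compounds than this note shows. Statements on the series, on what has been measured and on what is new or still open speak of the compounds shown alone.

For the measured compounds named here, in a physicochemical assay for lipophilicity, at pH 7.4 (on this read-out lower numbers stand for lower lipophilicity and higher numbers for higher lipophilicity), compound 2 `N#Cc1ccc(O[C@H]2CN(S(=O)(=O)c3ccccc3C#N)C[C@@]2(O)CO)cc1F` gives 3.4, the lower of the two numbers measured so far. Compound 1 `N#Cc1ccc(O[C@H]2CN(S(=O)(=O)c3ccc(Cl)cc3Cl)C[C@]2(O)CO)cc1F` gives 4.9, and the gap between the two lies beyond the scatter. Compound 3 `N#Cc1ccc(O[C@H]2CN(S(=O)(=O)c3ccc(Cl)cc3)C[C@@]2(O)CO)cc1F` has not yet been measured. It differs from compound 2 by 4-chlorophenyl in place of 2-cyanophenyl on a sulfonyl sulfur, with 4-chlorophenyl in place of 2-cyanophenyl on a sulfonyl sulfur. Going by the values given here, no two measured compounds differ in one place only, so no measured step gives the size of this change directly. Among the compounds with values here, compound 1, the only measured compound containing chlorine, stands at 4.9, and this is the sole support for expecting a rise. In this assay, the expected change is upward and beyond the scatter, estimated as a number 0.90 log units higher from compound 2 to compound 3 (beyond the scatter). For compound 3 the estimated value is 4.3, with an expected range of 3.8 to 4.8.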

Compound 3, distribution coefficient: 4.1
Beside the measured number, compound 3's estimate is 0.20 log units above it; the measured number falls inside the stated range.
By their numbers in this assay, from the lowest: compound 2; then compound 3; then compound 1.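

In this assay, the exchange of 2-cyanophenyl for 4-chlorophenyl on a sulfonyl sulfur gives a number 0.70 log units higher from compound 2 to compound 3 (beyond the scatter). For the compounds shown here, this is the first step that differs in one place only, so the group at the sulfonyl sulfur now has a measured effect on this read-out, with the rest of the compound held constant. Nothing available bears on the reason for the size of this step.

Going by these compounds, the step exchanges the substituent and its place on the phenyl ring together, so the share of each remains open. Also open, on these data alone, is where an unsubstituted phenyl, or a phenyl carrying an amine or a carboxylic acid, on the same sulfonyl sulfur would stand in this assay.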